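Alkoxy trimming at the pteridine-type series: compound 2 to compound 4

This account rests on a few compounds, and the source may have more. Where it says the series, first, only, none or still open, it means among the compounds named here.

Measured so far in a functional assay on cells (T-cell, Homo sapiens) for inhibition; on this read-out lower numbers stand for stronger inhibition and higher numbers for weaker inhibition:
- compound 1, `COc1ccc(-c2cnc3nc(N)nc(N4CCC(C)CC4)c3n2)cc1OC`, 800 nM
- compound 2, `CC(C)Oc1nc(N)nc2ncc(-c3ccc(F)c(F)c3)nc12`, 10000 nM
- compound 3, `COc1ccc(-c2cnc3nc(N)nc(N4CCN(C(=O)Nc5ccc(C)cc5)CC4)c3n2)cc1OC`, 0.8 nM

Compound 2 gives the highest number of the three in this assay. Compound 1 sits below it by a margin beyond the scatter, and compound 3 is lower still, far beyond the scatter; those two carry the dimethoxyphenyl arm and an amine on the shared core, whereas compound 2 carries a difluorophenyl arm and an isopropoxy group, so no single-change comparison among the measured compounds is available.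

Compound 4, `CCOc1nc(N)nc2ncc(-c3ccc(F)c(F)c3)nc12`, is not yet measured. It differs from compound 2 in one place: hydrogen in place of methyl on a saturated chain carbon bound to an oxygen on an aromatic ring and a saturated chain carbon. The remaining structure, the difluorophenyl arm and the amine on the shared core, is untouched.

Nothing measured in this set speaks to the removal of one carbon from this chain, so the expectation rests on the change being small. The step from compound 2 to compound 4 is expected to be none beyond the scatter, with compound 4 estimated near compound 2 at 10000 nM, within 3000 nM to 30000 nM, and the expected step from compound 2 to compound 4 is no change at the digits printed from compound 2 to compound 4 (within the scatter).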

Compound 4, half-maximal inhibitory concentration: > 10000 nM
Compound 4: only a limit was reported; the forecaster's own chance of this, stated with the estimate: 30%; the middle value lies on the limit itself.
By their numbers in this assay, from the lowest: compound 3; then compound 1; then compound 2.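

In this assay compound 4 gives > 10000 nM, which is a limit of the assay and not a number. Among these compounds, the change from isopropoxy to ethoxy is the first single-change comparison, and it gives a number no lower from compound 2 to compound 4 (the limit leaves the size open), so removing this methyl from the chain brings no visible gain in inhibition on the difluorophenyl arm. The size of the change cannot be read, because the result for compound 4 is a limit: the limit of > 10000 nM in this assay, at which 1 of the 4 values shown sits.

The compounds shown leave open whether a different group at this place, such as a longer chain like butoxy or an ethoxy chain ending in a hydroxyl group, would give a lower number than compound 2. They also leave open how the difluorophenyl arm and the alkoxy group each contribute to the distance from compound 1 and compound 3, and an isopropoxy or ethoxy group paired with the dimethoxyphenyl arm would separate the two.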